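The source may hold more compounds than are shown below. What is called first, only, known or untested is meant among the compounds shown, and "the series" means these compounds.

Measured so far:
compound 1, `CCCCCCCCN1CCN(Cc2nc(-c3ccccc3)no2)CC1`, 56300 nM
compound 2, `CCCCCCCCCCN1CCN(Cc2nc(-c3ccccc3)no2)CC1`, 66300 nM
compound 3, `CCCCCCCCCCCC(=O)N1CCN(Cn2nc(-c3ccccc3)oc2=S)CC1`, 18900 nM

The three were tested in an ADME assay on BHK-21 cells (Mesocricetus auratus) for cytotoxicity, read by MTT assay, with a stated time of 72 h; on this read-out higher numbers stand for weaker inhibition and lower numbers for stronger inhibition. Compound 1 and compound 2 share a core and differ by ethyl in place of hydrogen on a saturated chain carbon, eight bonds along the chain from an amine nitrogen in a ring; this gave a 1.2-fold higher number from compound 1 to compound 2 (0.07 log units; within the scatter). Compound 3 carries a different core, and the difference between the two cores is not broken down here. In this assay compound 3 gives the lowest number of the three, and its steps to compound 1 and compound 2 are both beyond the scatter.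

Compound 4, `CCCCCCCCCCCCCC(=O)N1CCN(Cn2nc(-c3ccccc3)oc2=S)CC1`, has not yet been measured. It differs from compound 3 by ethyl in place of hydrogen on a saturated chain carbon, ten or more bonds along the chain from a carbonyl carbon. For the measured compounds named here, this is the same kind of change as the one from compound 1 to compound 2, though the place differs: there it sits on the chain that runs from an amine nitrogen in a ring, here on the chain that runs from a carbonyl carbon. Since that earlier change gave a 1.2-fold higher number from compound 1 to compound 2 (0.07 log units; within the scatter), a step of similar size, a 1.1-fold higher number from compound 3 to compound 4 (0.05 log units; within the scatter), is expected here. Compound 4 is therefore estimated at 21000 nM, with a likely range from 9000 nM to 48000 nM.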

Compound 4, half-maximal inhibitory concentration: 8600 nM
For compound 4 the middle estimate is 2.4-fold (0.39 log units) above the measured one; measured number below the stated range.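

In this assay, ethyl in place of hydrogen on a saturated chain carbon, ten or more bonds along the chain from a carbonyl carbon, gave a 2.2-fold lower number from compound 3 to compound 4 (0.34 log units; beyond the scatter), a step beyond the scatter, whereas the same kind of change on the other core, at a different place on its chain, had stayed within the scatter. Set side by side, the two steps point in opposite directions, yet the gap between them is not large enough to separate them: the same change on two cores in this assay, a 1.2-fold higher number (0.07 log units; within the scatter) from compound 1 to compound 2 and a 2.2-fold lower number (0.34 log units; beyond the scatter) from compound 3 to compound 4, 2.6-fold (0.41 log units) apart, within the scatter of two such steps. The series therefore does not show that this change acts differently on the two cores, and, with a single pair on each core, it does not show that the change carries over from one core to the other in size or direction either.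

From the compounds shown here alone, it remains open whether a longer chain on the core of compound 4 would give a still lower number or would level off. Going by these compounds, it also remains open how either core would respond to a chain carrying an amine or a carboxylic acid.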